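Replacing Chlorophenyl with Dimethylphenyl in a Flavonol Amide Series

A few compounds are considered here, and "the series" means these few. Any claim that something is new, unique, unknown or untested is made for them only; others in the source may bear on it.

Compound 1 `O=C(Nc1cccc(-c2oc3cc(-c4ccc(F)cc4)ccc3c(=O)c2O)c1)c1ccc(Cl)cc1` gives 4730 nM in a functional assay on MCF7 cells (Homo sapiens) for antiproliferative activity, read by CCK-8 assay, with a stated time of 72 h; a higher number here means a weaker inhibitor, a lower number a stronger inhibitor; compound 2 `O=C(Nc1cccc(-c2oc3cc(-c4ccc(F)cc4)ccc3c(=O)c2O)c1)c1cccc(F)c1` gives 5770 nM; compound 3 `CCc1ccc(C(=O)Nc2cccc(-c3oc4cc(-c5ccc(F)cc5)ccc4c(=O)c3O)c2)cc1` gives 22800 nM.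

Compound 1 holds the lowest number of the three, with compound 2 close by (a 1.2-fold higher number from compound 1 to compound 2 (0.09 log units; within the scatter)) and compound 3 further off (a 4.8-fold higher number from compound 1 to compound 3 (0.68 log units; beyond the scatter)). Compound 4 `Cc1cc(C)cc(C(=O)Nc2cccc(-c3oc4cc(-c5ccc(F)cc5)ccc4c(=O)c3O)c2)c1` differs from compound 1 by 3,5-dimethylphenyl in place of 4-chlorophenyl on a carbonyl carbon. Among the measured compounds shown here, the step that bears on it most is the one where an alkyl group replaced a halogen, a 4.8-fold higher number from compound 1 to compound 3 (0.68 log units; beyond the scatter), echoed by a 4.0-fold higher number from compound 2 to compound 3 (0.60 log units; beyond the scatter). Both point the same way, so a modest rise is expected for compound 4, a 2.3-fold higher number from compound 1 to compound 4 (0.37 log units; beyond the scatter). Compound 4 is therefore estimated at 11000 nM, within 4500 nM to 27000 nM.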

Compound 4, half-maximal inhibitory concentration: 20400 nM
For compound 4 the middle estimate is 1.9-fold (0.27 log units) below the measured one; the range from low to high includes it.
By their numbers in this assay, from the lowest: compounds 1 and 2 (each within the scatter of the next); then compounds 4 and 3 (each within the scatter of the next).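

In this assay, the 3,5-dimethylphenyl amide cannot be told apart from the 4-ethylphenyl amide (a 1.1-fold lower number from compound 3 to compound 4 (0.05 log units; within the scatter)), while its gap to the halogen-bearing amides is beyond the scatter (a 4.3-fold higher number from compound 1 to compound 4 (0.63 log units; beyond the scatter) and a 3.5-fold higher number from compound 2 to compound 4 (0.55 log units; beyond the scatter)). Among these four compounds, the two alkyl-bearing rings therefore group together, apart from the two halogen-bearing rings, whether the ring carries one ethyl or two methyl groups. Nothing shown here explains this split. The compounds shown leave open whether an unsubstituted phenyl, a methoxy or an amine on this ring would fall with the halogen pair or the alkyl pair.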